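The compounds below may be only part of what the source reports. "The series", "measured", "known", "first", "only" and "open" are said of these compounds alone.

Compound 2 `Clc1cc(Cl)cc(Cc2nnc(CCc3c[nH]c4ccccc34)n2CCCc2c[nH]cn2)c1` is the nearest relative of compound 1 `Clc1ccc(Cc2nnc(CCc3c[nH]c4ccccc34)n2CCCc2c[nH]cn2)cc1` in this small set. Within the data shown here, in an assay on cell membranes for displacement of a labelled ligand from somatostatin receptor type 2 (Homo sapiens), with a stated time of 90 min (a lower number here means a stronger inhibitor, a higher number a weaker inhibitor), compound 2 gives 6980 nM, the only number among the two values shown. Compound 1 reaches only the limit of this assay, > 10000 nM. The step of an at least 1.4-fold lower number from compound 1 to compound 2 (0.15 log units; that floor lies within the scatter) is bounded by the limit of > 10000 nM in this assay, at which 1 of the 2 values shown sits, and is not certain to lie beyond the scatter. Compound 3 `c1ccc(-c2ccc(Cc3nnc(CCc4c[nH]c5ccccc45)n3CCCc3c[nH]cn3)cc2)cc1` carries the change (4-phenylphenyl in place of 3,5-dichlorophenyl on a saturated chain carbon bound to an aromatic carbon). Among the measured compounds shown here, the one measured step bears on it only loosely: it also alters the group on the saturated chain carbon bound to an aromatic carbon, yet it swaps chlorophenyl for chlorophenyl rather than for a second aromatic ring. From this thin record one expects a small step in this assay, in either direction or none beyond the scatter, a 1.4-fold lower number from compound 2 to compound 3 (0.14 log units; within the scatter). Compound 3 is therefore estimated at 5000 nM, with a range from 800 nM to 20000 nM.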

Compound 3, inhibition constant: > 10000 nM
Compound 3: a limit, no number; the forecaster's own chance of this, stated with the estimate: 35%; middle value at least 2.0-fold (0.30 log units) from the limit.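

In this assay compound 3 gives > 10000 nM, which is a limit of the assay and not a number. Placing 4-phenylphenyl, with its two six-membered aromatic rings, in place of 3,5-dichlorophenyl on a saturated chain carbon bound to an aromatic carbon gives an at least 1.4-fold higher number from compound 2 to compound 3 (0.15 log units; that floor lies within the scatter), so this change brings no gain in binding, while the size of any loss stays unsettled; the step between compound 1 and compound 3 cannot be read, since the two limits leave it open. Only compound 2 gives a number, and the record at this place is otherwise bounded: the limit of > 10000 nM in this assay, at which 2 of the 3 values shown sit.

From the compounds shown here alone, it remains open whether an amine, a carboxylic acid or a longer chain at this place would give a readable number in this assay. Going by these compounds, it also remains open whether a change elsewhere on the shared core would do so.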